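Trading trifluoromethyl for benzyloxy in compound 1

A few compounds are considered here, and "the series" means these few. Any claim that something is new, unique, unknown or untested is made for them only; others in the source may bear on it.

Three compounds share one core and differ only in the group on the sulfonyl sulfur. In an ADME assay on microsomes (Homo sapiens) for metabolic stability (on this read-out lower numbers stand for slow clearance and higher numbers for fast clearance), compound 1 `CNC(=O)[C@@H]1CCCN1S(=O)(=O)c1ccc(Cl)c(COc2cccc3c(C(F)(F)F)cc(C)nc23)c1Cl` gives 250 mL/min/kg. Alongside it, compound 2 `Cc1cc(C(F)(F)F)c2cccc(OCc3c(Cl)ccc(S(=O)(=O)N4C[C@@H](C)O[C@@H](C)C4)c3Cl)c2n1` gives 317 mL/min/kg, and compound 3 `Cc1cc(C(F)(F)F)c2cccc(OCc3c(Cl)ccc(S(=O)(=O)N4CCC(C#N)CC4)c3Cl)c2n1` gives 433 mL/min/kg. These numbers lie within the usual scatter of one another, so compound 1 does not stand apart from its two neighbours.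

The measured steps are a 1.3-fold higher number from compound 1 to compound 2 (0.10 log units; within the scatter), a 1.7-fold higher number from compound 1 to compound 3 (0.24 log units; within the scatter) and a 1.4-fold higher number from compound 2 to compound 3 (0.14 log units; within the scatter). Each of them changes only the group on the sulfonyl sulfur.

Compound 4 `CNC(=O)[C@@H]1CCCN1S(=O)(=O)c1ccc(Cl)c(COc2cccc3c(OCc4ccccc4)cc(C)nc23)c1Cl` keeps the 2-(methylcarbamoyl)pyrrolidin-1-yl group of compound 1 and changes a different place: benzyloxy in place of trifluoromethyl on an aromatic carbon. Within the data shown here, no measured step touches that place, so these steps give only indirect guidance. They show how little these three compounds differ, but they say nothing about replacing trifluoromethyl.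

With no evidence for a direction, no step beyond the scatter is expected in this assay. The expected step is a 1.2-fold higher number from compound 1 to compound 4 (0.08 log units; within the scatter), and this estimate is deliberately modest. For compound 4 the estimated clearance is 300 mL/min/kg, with an expected range from 150 mL/min/kg to 600 mL/min/kg.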

Compound 4, clearance: 467 mL/min/kg
Estimate against measurement, compound 4: 1.6-fold (0.19 log units) below; the range from low to high includes it.
By their numbers in this assay, from the lowest: compounds 1, 2, 3 and 4 (each within the scatter of the next).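

Among these compounds, at this place on the ring, opposite the ring nitrogen, the earlier compounds all carry trifluoromethyl, so they could say nothing about changing it. In this assay, replacing that group of 4 heavy atoms with benzyloxy, which has 8 heavy atoms, an aromatic ring of carbon and a hydrogen-bond acceptor, gives a 1.9-fold higher number from compound 1 to compound 4 (0.27 log units; within the scatter), so for this one pair a considerably larger group does not shift the number beyond the usual scatter of repeat measurements. Nothing available here accounts for the size or direction of this step.

The compounds shown leave open whether a smaller oxygen-linked group such as methoxy, or a charged-capable group such as an amine or a carboxylic acid, would behave the same way at this place. They also leave open whether benzyloxy gives a similar result when paired with the 4-cyanopiperidin-1-yl group of compound 3 or the 2,6-dimethylmorpholin-4-yl group of compound 2, rather than the 2-(methylcarbamoyl)pyrrolidin-1-yl group it sits with here.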